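Stability of Two Fused Bicyclic Amides and a Third

The compounds below may be only part of what the source reports. "The series", "measured", "known", "first", "only" and "open" are said of these compounds alone.

Measured compounds:
- compound 1, `O=C(NCc1ccc(S(=O)(=O)c2ccccc2)cc1)c1cc2ccncc2s1`, 21%
- compound 2, `O=C(NCc1ccc(S(=O)(=O)c2ccccc2)cc1)c1cn2ccnc2cn1`, 13%

In an ADME assay on microsomes from liver (Mus musculus) for metabolic stability, read by LC-MS, with a stated time of 30 min, tested at 1 uM (a higher number here means that more of the compound is left, a lower number that less of the compound is left), compound 2 gives the lowest of the two numbers; compound 1 stands nearest, at a step of a number 8 percentage points lower from compound 1 to compound 2 (within the scatter). Compound 3, `O=C(NCc1ccc(S(=O)(=O)c2ccccc2)cc1)c1ccc2nccn2c1`, has not yet been measured in this assay. Its change from compound 2 is a group of 9 heavy atoms (7 carbon, 2 nitrogen; one five-membered aromatic ring with 2 hetero atoms, one six-membered aromatic ring with 1 hetero atom) in place of a group of 9 heavy atoms (6 carbon, 3 nitrogen; one five-membered aromatic ring with 2 hetero atoms, one six-membered aromatic ring with 2 hetero atoms), on a carbonyl carbon. Among the measured compounds shown here, the only measured step that bears on it, a number 8 percentage points lower from compound 1 to compound 2 (within the scatter), also swaps the whole group on the carbonyl carbon and stayed within the scatter. Compound 3 is therefore expected to sit close to compound 2, with a step of a number 3 percentage points higher from compound 2 to compound 3 (within the scatter), and is estimated at 16%, within 5% to 32%.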

Compound 3, percent of the compound remaining: 18%
The estimate for compound 3 lay 2 percentage points below the measured number; the range from low to high includes it.
By their numbers in this assay, from the lowest: compounds 2, 3 and 1 (each within the scatter of the next).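

In this assay, a third fused group on the carbonyl carbon again stays within the scatter, as shown by a number 5 percentage points higher from compound 2 to compound 3 (within the scatter) and by a number 3 percentage points lower from compound 1 to compound 3 (within the scatter). Trading a six-membered aromatic ring with 2 hetero atoms for one with 1 hetero atom therefore produces no change that can be told from the scatter. Nothing available explains these numbers. From the compounds shown here alone, it remains open whether a group of another kind on the carbonyl carbon, such as a morpholine or a simple phenyl, would move the number beyond the scatter. Going by these compounds, the effect of changes elsewhere in the shared core also remains open.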